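The source may report more compounds than this note shows. Statements on the series, on what has been measured and on what is new or still open speak of the compounds shown alone.

In an ADME assay on Chem1 cells (Homo sapiens) for cytotoxicity (on this read-out higher numbers stand for lower toxicity in this test and lower numbers for higher toxicity in this test), compound 3 `NCCCCN(C[C@H]1CN(S(=O)(=O)c2ccc(Cl)cc2)CCN1)[C@H]1CCCc2cccnc21` gives > 10 uM, which is a limit of the assay and not a number. Compound 1 `NCCCCN(C[C@H]1CN(C(=O)OCc2ccccc2)CCN1)[C@H]1CCCc2cccnc21` gives > 10 uM, which is also a limit. Compound 2 `NCCCCN(C[C@H]1CN(S(=O)(=O)c2ccc3ccccc3c2)CCN1)[C@H]1CCCc2cccnc21` gives > 10 uM, again a limit. Compound 3 therefore has no exact value and stands with the other two at the limit of > 10 uM in this assay, at which 3 of the 3 values shown sit.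

Compound 4 `NCCCCN(C[C@H]1CN(C(=O)Nc2ccccc2)CCN1)[C@H]1CCCc2cccnc21` differs from compound 3 by a single change, phenylcarbamoyl in place of (4-chlorophenyl)sulfonyl on an amine nitrogen in a ring. Among the measured compounds shown here, two measured steps bear on this change. Putting (4-chlorophenyl)sulfonyl in place of benzyloxycarbonyl on an amine nitrogen in a ring is a step that the two limits leave unreadable from compound 1 to compound 3. Putting 4-chlorophenyl in place of naphthalen-2-yl on a sulfonyl sulfur is a step that the two limits leave unreadable from compound 2 to compound 3. Neither step has a size that can be carried over. All three groups shown on that nitrogen leave the read-out at the limit, so no step beyond the scatter is expected in this assay, and no direction can be given. The expected change is a step that the limit leaves unreadable from compound 3 to compound 4. Compound 4 is estimated at 14 uM, with an expected range from 6 uM to 35 uM.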

Compound 4, half-maximal toxic concentration: > 10 uM
Compound 4: only a limit was reported; the forecaster's own chance of this, stated with the estimate: 85%; the middle value lies beyond the limit too.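

No new step can be read: the steps from compound 3 and from compound 1 to compound 4 join two limits, so their sizes stay unreadable. Compound 4 stands with compounds 1, 2 and 3 in this assay: the limit of > 10 uM in this assay, at which 4 of the 4 values shown sit. The compounds shown leave open whether any of these groups on the ring nitrogen changes the read-out, and at what concentration any of the four compounds turns toxic.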